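Benzyl versus aryl on the triazole carbon of the series

The compounds below may be only part of what the source reports. "The series", "measured", "known", "first", "only" and "open" are said of these compounds alone.

Measured so far:
compound 1 `Cc1ccc(Cc2nc3[nH]c(-c4ccc(Cl)cc4)cc(=O)n3n2)cc1` — 5440 nM
compound 2 `Cc1ccc(-c2nc3[nH]c(-c4ccccc4)cc(=O)n3n2)cc1` — 3210 nM

Both compounds were run in a functional assay on Cortical neurone cells (Mus musculus, strain C57BL/6), read by FLIPR and calcium flux, with a stated time of 8 min; a higher number here means a weaker inhibitor, a lower number a stronger inhibitor. Compound 1 gives 5440 nM and compound 2 gives 3210 nM. On the numbers shown, compound 2 carries the lower of the two values, but the two values lie within the scatter of each other, so neither compound can be called the stronger inhibitor. Among the compounds with values here, compound 1 and compound 2 differ at more than one place, so no single step between measured compounds is available.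

Compound 3 `O=c1cc(-c2ccccc2)[nH]c2nc(Cc3ccc(F)cc3)nn12` has not yet been measured in this assay. It is built from compound 2 by one change: 4-fluorobenzyl in place of 4-methylphenyl on an aromatic carbon. Within the data shown here, there is no measured pair that isolates this change, so its effect is unknown.

Given that both measured compounds sit close together in this assay, the expectation for compound 3 is a step from compound 2 of no more than the scatter in either direction, estimated as a 1.1-fold higher number from compound 2 to compound 3 (0.04 log units; within the scatter). Compound 3 is therefore expected to come out near 3500 nM, within a range of 1400 nM to 9000 nM.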

Compound 3, half-maximal inhibitory concentration: 2520 nM
For compound 3 the middle estimate is 1.4-fold (0.14 log units) above the measured one; the range from low to high includes it.
By their numbers in this assay, from the lowest: compounds 3, 2 and 1 (each within the scatter of the next, the first and the last beyond it).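

In this assay, 4-fluorobenzyl in place of 4-methylphenyl on the aromatic carbon between two ring nitrogen atoms gives the series its first step at a single place, with a 1.3-fold lower number from compound 2 to compound 3 (0.11 log units; within the scatter) as the result. This position therefore carries either of these two groups on the shared core without a difference that can be read in this assay, which the earlier pair of compounds, differing at more than one place, could not show. No measurement at hand accounts for this result.

The step from compound 2 to compound 3 swaps the aryl group for a benzyl group and the methyl substituent for fluorine together, so the contribution of each remains unresolved, and a single step within the scatter does not show that either contribution is small, since the two could offset each other. The compounds shown also leave open how the position responds to groups of another kind, such as an amine, a carboxylic acid or a longer chain like 2-phenylethyl, all of which would test it more widely than these two groups do.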